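Swapping the Aryl Group on the Piperazine Nitrogen

The source may report more compounds than this note shows. Statements on the series, on what has been measured and on what is new or still open speak of the compounds shown alone.

Of the compounds shown here, three that share one core have been tested in a functional assay on HL-60 cells (Homo sapiens) for inhibition, read by MTT assay, with a stated time of 72 h; on this read-out higher numbers stand for weaker inhibition and lower numbers for stronger inhibition. Compound 1, with structure `CCc1nc(-c2cccc(F)c2)c(C(=O)N2CCN(c3cccc(OC)c3)CC2)o1`, gives 201 nM in this assay. Compound 2, with structure `COc1cccc(N2CCN(C(=O)c3oc(C(F)(F)F)nc3-c3cccc(F)c3)CC2)c1`, was recorded as "not active" (no number reported) in this assay, so no number is available for it. Compound 3, with structure `Cc1nc(-c2ccccc2)c(C(=O)N2CCN(c3ccc(Cl)c(Cl)c3)CC2)o1`, gives 124 nM in this assay. Among the two compounds that have a number, compound 3 has the lower one, but its gap to compound 1 lies within the usual scatter of this assay, so the two cannot be told apart.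

Compound 4, with structure `Cc1nc(-c2ccccc2)c(C(=O)N2CCN(c3ccccc3Cl)CC2)o1`, has not yet been measured. It differs from compound 3 in one place: 2-chlorophenyl in place of 3,4-dichlorophenyl on an amine nitrogen in a ring. Going by the values given here, no measured pair shows what such a swap does to the number in this assay, so the size of the step is open. The step from compound 3 to compound 4 is expected to be small, perhaps a mild weakening, with the estimated change being a 2.4-fold higher number from compound 3 to compound 4 (0.38 log units; beyond the scatter). Compound 4 is therefore expected to give about 300 nM in this assay, likely between 90 nM and 1000 nM.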

Compound 4, half-maximal inhibitory concentration: 124 nM
Estimate against measurement, compound 4: 2.4-fold (0.38 log units) above; the range from low to high includes it.
By their numbers in this assay, from the lowest: compounds 3, 4 and 1 (each within the scatter of the next).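

Going by these compounds alone, putting 2-chlorophenyl in place of 3,4-dichlorophenyl on the amine nitrogen of the piperazine-type ring gives no change at the digits printed from compound 3 to compound 4 (within the scatter) in this assay, the first step at this position that can be read. In this one pair, then, the chlorine pattern on the phenyl ring can differ without a readable shift in the number, although a single pair cannot set a general rule for the position. Nothing measured here bears on why the number holds.

Going by these compounds, whether a phenyl ring with no chlorine, or one carrying an amine or a carboxylic acid, would also leave the number in place remains open. Compound 1 and compound 2 differ from this pair in more than one place, so steps involving them cannot be read.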